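Swapping Chloro for Methyl in a Growth-Inhibitor Series

The compounds below may be only part of what the source reports. "The series", "measured", "known", "first", "only" and "open" are said of these compounds alone.

Measured compounds and their values:
- compound 1 `C=CC(=O)Nc1cc(Nc2ncc(Cl)c(Nc3ccccc3S(=O)(=O)C(C)C)n2)c(OC)cc1N1CCC(N2CCN(C)CC2)CC1`: 23 nM
- compound 2 `C=CC(=O)Nc1cc(Nc2ncc(Cl)c(Nc3ccccc3S(=O)(=O)C(C)C)n2)c(OC)cc1N1CCCCC1`: 240 nM
- compound 3 `C=CC(=O)Nc1cc(Nc2ncc(Cl)c(Nc3ccccc3S(=O)(=O)C(C)C)n2)ccc1N1CCC(N2CCN(C)CC2)CC1`: 7100 nM

These three compounds were tested in a functional assay on NCI-H1975 cells (Homo sapiens) for inhibition, read by CellTiter-Glo, with a stated time of 72 h; a lower number here means a stronger inhibitor of growth, a higher number a weaker inhibitor of growth. Compound 1 gives the lowest number of the three in this assay. Removing the 4-methylpiperazin-1-yl group from the saturated ring gives a 10-fold higher number from compound 1 to compound 2 (1.02 log units; beyond the scatter), and removing the methoxy group from the aromatic carbon gives a 310-fold higher number from compound 1 to compound 3 (2.49 log units; beyond the scatter). Both changes sit on the same part of the molecule, the ring that carries the acrylamide, and both leave the rest untouched.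

Compound 4 `C=CC(=O)Nc1cc(Nc2ncc(C)c(Nc3ccccc3S(=O)(=O)C(C)C)n2)c(OC)cc1N1CCC(N2CCN(C)CC2)CC1` has not been measured in this assay. It differs from compound 1 in a different place: methyl in place of chloro on an aromatic carbon. The change sits on the six-membered aromatic ring with 2 nitrogen, two atoms from the ring nitrogen, ortho to a large group and para to a large group.

Within the data shown here, neither of the measured steps touches this ring, so no measured step bears directly on the swap. The two known steps show that the potency of compound 1 is sensitive to changes elsewhere, but nothing here tells how the ring with 2 nitrogen responds. A modest loss is expected, because a one-atom swap of two small uncharged groups is unlikely to match the large effects seen in a 310-fold higher number from compound 1 to compound 3 (2.49 log units; beyond the scatter). For compound 4 the expected value in this assay is 60 nM, with a range from 15 nM to 250 nM, which is an expected step of a 2.6-fold higher number from compound 1 to compound 4 (0.42 log units; beyond the scatter).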

Compound 4, concentration for 50% growth inhibition: 27 nM
Compound 4: middle estimate off by 2.2-fold (0.35 log units), on the high side; measured number inside the range.
By their numbers in this assay, from the lowest: compounds 1 and 4 (each within the scatter of the next); then compound 2; then compound 3.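

In this assay the swap gives a 1.2-fold higher number from compound 1 to compound 4 (0.07 log units; within the scatter) and so makes no readable difference at this position, on the six-membered aromatic ring with 2 nitrogen, two atoms from the ring nitrogen. The two earlier steps both changed the ring that carries the acrylamide and both lay beyond the scatter, whereas this first look at the other ring shows that chloro and methyl can stand in for each other here, at least with the rest of compound 1 unchanged. No measurement shown here gives a reason why these two groups read alike in this assay.

The compounds shown leave open whether this carbon accepts groups other than these two, such as a nitrile, a trifluoromethyl, a bare hydrogen or a longer chain like propyl, any of which would show how far the freedom at this position extends. They also leave open whether methyl and chloro still read alike without the 4-methylpiperazin-1-yl group or the methoxy group, as methyl is shown here only on the full framework of compound 1.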